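Switching the Ring on a Sulfonamide Bradykinin Antagonist

The source may report more compounds than this note shows. Statements on the series, on what has been measured and on what is new or still open speak of the compounds shown alone.

Compound 1 `CN(Cc1ccc(C2=NCCN2)cc1)C(=O)COCCN(C)S(=O)(=O)c1c(Cl)cccc1Cl` is the higher of the two compounds measured in a functional assay for antagonist activity at B1 bradykinin receptor (Mus musculus), using Schild analysis, with a stated time of 30 min (a higher number here means a more potent compound, by a factor of ten per unit of this negative logarithm, a lower number a less potent compound), giving 7.2. Compound 2 `Cc1c(Cl)ccc(S(=O)(=O)N(C)CCC(=O)N(C)Cc2ccc(C3=NCCN3)cc2)c1Cl` gives 6.4 in this assay, a value that lies beyond the usual scatter below that of compound 1. Compound 3 `Cc1c(Cl)ccc(S(=O)(=O)N(C)CCOCC(=O)N(C)Cc2ccc(C3=NCCN3)cc2)c1Cl` keeps the core of compound 1 and changes only the ring on the sulfonyl sulfur: 2,4-dichloro-3-methylphenyl in place of 2,6-dichlorophenyl on a sulfonyl sulfur. Going by the values given here, with no measured pair isolating this change, a modest decrease in this assay is expected, estimated as a number 0.40 log units lower from compound 1 to compound 3 (beyond the scatter). Compound 3 is therefore expected to give about 6.8 in this assay, within a range from 6.2 to 7.4.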

Compound 3, negative logarithm of the antagonist equilibrium constant: 7.5
The estimate for compound 3 lay 0.70 log units below the measured number; measured number above the stated range.
By their numbers in this assay, from the lowest: compound 2; then compounds 1 and 3 (each within the scatter of the next).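

On a sulfonyl sulfur whose other neighbour is the sulfonamide nitrogen, 2,4-dichloro-3-methylphenyl in place of 2,6-dichlorophenyl gives a number 0.30 log units higher from compound 1 to compound 3 (within the scatter) in this assay, so the two rings cannot be told apart here. This position therefore accommodates both substitution patterns on the shared core, including the one with an added methyl group. Nothing available accounts for this result. Still open, from the compounds shown here alone, is how this position would respond to a ring bearing an amine or a carboxylic acid. Also open, going by these compounds, is whether an unsubstituted phenyl ring would match these two dichlorinated rings.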